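Replacing 2-fluorophenyl in compound 3: working notes

This account rests on a few compounds, and the source may have more. Where it says the series, first, only, none or still open, it means among the compounds named here.

In a functional assay on HT-29 cells (Homo sapiens) for inhibition, read by CCK-8 assay, with a stated time of 24 h (on this read-out lower numbers stand for stronger inhibition and higher numbers for weaker inhibition), compound 1 `Cc1cccc(-n2cc(-c3ccc(/C=C4\C(=O)Nc5ccccc54)cc3)nn2)c1` gives 3940 nM, compound 2 `O=C1Nc2ccccc2/C1=C/c1ccc(-c2cn(-c3ccccc3F)nn2)cc1` gives 10500 nM and compound 3 `O=C1Nc2ccc(F)cc2/C1=C/c1ccc(-c2cn(-c3ccccc3F)nn2)cc1` gives 8980 nM. Compound 3 therefore sits level with compound 2, and both lie above compound 1.

The next structure is compound 4 `N#Cc1cccc(-n2cc(-c3ccc(/C=C4\C(=O)Nc5ccc(F)cc54)cc3)nn2)c1`, which carries 3-cyanophenyl in place of 2-fluorophenyl on an aromatic nitrogen. It keeps the fluoro of compound 3 on the shared core.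

For the measured compounds named here, two measured steps bear on this change. The closer one is a 2.7-fold higher number from compound 1 to compound 2 (0.43 log units; beyond the scatter), made at the same aromatic nitrogen. There 2-fluorophenyl is the group that enters, whereas here it leaves, which points toward a lower number. The other is a 1.2-fold lower number from compound 2 to compound 3 (0.07 log units; within the scatter). It concerns the retained fluoro, so no separate contribution is expected from that site.

Going by the values given here, no measured compound carries 3-cyanophenyl, so the size of the step rests on a single precedent and remains uncertain. Among the compounds with values here, a modest move toward stronger inhibition is expected, no larger than the precedent. The expected change is a 2.0-fold lower number from compound 3 to compound 4 (0.30 log units; within the scatter). For compound 4 the estimated value is 4500 nM, with an expected range of 1800 nM to 11000 nM.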

Compound 4, half-maximal inhibitory concentration: > 20000 nM
Compound 4 was reported as a limit (the forecaster's own chance of this, stated with the estimate: 3%); at least 4.4-fold (0.64 log units) between middle value and limit.
By their numbers in this assay, from the lowest: compound 1; then compounds 3 and 2 (each within the scatter of the next). At a limit, above all of these: compound 4.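

In this assay compound 4 is reported only as a limit, > 20000 nM, and not as a number. Putting 3-cyanophenyl in place of 2-fluorophenyl on the aromatic nitrogen gives an at least 2.2-fold higher number from compound 3 to compound 4 (0.34 log units; beyond the scatter), so losing 2-fluorophenyl does not in itself lower the number at this position, and the earlier step at the same nitrogen, a 2.7-fold higher number from compound 1 to compound 2 (0.43 log units; beyond the scatter), does not carry over to this new group. Among the compounds shown, compound 4 alone stands at this limit: the limit of > 20000 nM in this assay, at which 1 of the 4 values shown sits.

For the compounds shown here, it remains open whether 3-cyanophenyl gives the same result on the shared core without the fluoro, since the only step at that site, a 1.2-fold lower number from compound 2 to compound 3 (0.07 log units; within the scatter), was read with 2-fluorophenyl on the aromatic nitrogen. Also open, on these data alone, is how the number in this assay responds when the phenyl on that nitrogen carries an amine or a carboxylic acid.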